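This account rests on a few compounds, and the source may have more. Where it says the series, first, only, none or still open, it means among the compounds named here.

Compound 1 `CC(C)(CO)CNC(=O)c1cc2cc(C#N)ccc2n1Cc1cc(Cl)cc(Cl)c1`: in an in vitro ADME assay on microsomes from Gut (Homo sapiens) for metabolic stability, using NADPH (on this read-out lower numbers stand for slow clearance and higher numbers for fast clearance), compound 1 gives < 6 mL.min-1.g-1, which is a limit of the assay rather than a number.
Compound 2 `COc1ccc(Cl)cc1Cn1c(C(=O)NCC(C)(C)CO)cc2cc(C#N)ccc21`: compound 2 gives < 6 mL.min-1.g-1, again only a limit.
Compound 3 `Cc1ccc(Cl)cc1Cn1c(C(=O)NCC(C)(C)CO)cc2cc(C#N)ccc21`: compound 3 gives < 6 mL.min-1.g-1, also a limit.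

Compound 1 therefore stands only at a limit in this assay, and the two further values shown are limits as well; all three values sit at the limit of < 6 mL.min-1.g-1 in this assay, at which 3 of the 3 values shown sit. The steps a step that the two limits leave unreadable from compound 1 to compound 2 and a step that the two limits leave unreadable from compound 1 to compound 3, and likewise a step that the two limits leave unreadable from compound 2 to compound 3, have no readable size or direction: both ends of each step are limits.

Compound 4 `Cc1ccc(C)c(Cn2c(C(=O)NCC(C)(C)CO)cc3cc(C#N)ccc32)c1` has not yet been measured in this assay. It differs from compound 1 by 2,5-dimethylphenyl in place of 3,5-dichlorophenyl on a saturated chain carbon bound to an aromatic nitrogen. Going by the values given here, the steps that bear on this change are the three unreadable ones, so nothing in them points to a movement beyond the scatter. Compound 4 is therefore expected to show the step that the limit leaves unreadable from compound 1 to compound 4, that is, to remain at the same limit. The estimate for compound 4 is 4 mL.min-1.g-1, ranging from 1 mL.min-1.g-1 to 10 mL.min-1.g-1.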

Compound 4, intrinsic clearance in microsomes: < 6 mL.min-1.g-1
Compound 4 was reported as a limit; the forecaster's own chance of this, stated with the estimate: 75%; the middle value is on the limit's open side.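

Going by these compounds alone, compound 4, like compound 1, compound 2 and compound 3, stands only at a limit in this assay, so no step among them can be read: the limit of < 6 mL.min-1.g-1 in this assay, at which 4 of the 4 values shown sit. The compounds shown leave open what their actual clearances are and whether exchanging these substituted phenyl groups changes clearance at all.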